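Series notes: the 2-bromoethoxy step from compound 1

The source may report more compounds than this note shows. Statements on the series, on what has been measured and on what is new or still open speak of the compounds shown alone.

Compound 1 `COc1ccc(N(C)c2ccnc(Cl)n2)cc1` is the parent of this small set. Going by the values given here, in a functional assay on MDA-MB-231 cells (Homo sapiens) for antiproliferative activity, read by MTT assay, with a stated time of 48 h (on this read-out higher numbers stand for weaker inhibition and lower numbers for stronger inhibition), compound 1 gives 2820 nM, the second highest of the three numbers so far. Compound 2 `COc1ccc(N(C)c2ccnc(Cl)n2)cc1F` gives 1280 nM, and a 2.2-fold lower number from compound 1 to compound 2 (0.34 log units; beyond the scatter). Compound 3 `COc1ccc(N(C)c2ccnc(Cl)n2)cc1[N+](=O)[O-]` gives 8120 nM, and a 2.9-fold higher number from compound 1 to compound 3 (0.46 log units; beyond the scatter); between the two substituted analogues, a 6.3-fold higher number from compound 2 to compound 3 (0.80 log units; beyond the scatter).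

The next step keeps the shared core of compound 1 and adds a larger group: compound 4 `COc1ccc(N(C)c2ccnc(Cl)n2)cc1OCCBr` carries 2-bromoethoxy in place of hydrogen on an aromatic carbon, placed ortho to a methoxy group. Neither measured step bears directly on it, since the fluoro step was modest downward and the nitro step modest upward, and both replaced hydrogen with a single heavy atom or a small group rather than a 2-bromoethoxy chain. With the two known steps pointing in opposite directions, a step beyond the scatter is expected in neither direction with any confidence, so compound 4 is estimated at 2500 nM, in the range 900 nM to 7000 nM, meaning a 1.1-fold lower number from compound 1 to compound 4 (0.05 log units; within the scatter) is expected to be about nil.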

Compound 4, half-maximal inhibitory concentration: 6620 nM
Compound 4: the middle estimate sits 2.6-fold (0.42 log units) below what was measured, within the range that was stated.
By their numbers in this assay, from the lowest: compound 2; then compound 1; then compounds 4 and 3 (each within the scatter of the next).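

At this aromatic carbon, ortho to a methoxy group, the 2-bromoethoxy chain is a second replacement of hydrogen that raises the number in this assay (a 2.3-fold higher number from compound 1 to compound 4 (0.37 log units; beyond the scatter)), after the nitro group of compound 3. The larger chain and the nitro group cannot be told apart (a 1.2-fold lower number from compound 3 to compound 4 (0.09 log units; within the scatter)), so the size of the entering group does not by itself set the number across these compounds. Fluoro remains the only change here that lowers the number, and the gap to the chain is wider than the step from hydrogen (a 5.2-fold higher number from compound 2 to compound 4 (0.71 log units; beyond the scatter)). Nothing available on these compounds explains the differences.

As far as these compounds go, it remains open whether the bromine or the chain carries the step, which a plain ethoxy group or a 2-hydroxyethoxy chain would separate. A longer chain or one ending in an amine would show whether the number keeps moving with the chain.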